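Swapping a Benzyl Arm While Cell Toxicity Stays Low

This account rests on a few compounds, and the source may have more. Where it says the series, first, only, none or still open, it means among the compounds named here.

Going by the values given here, compound 1 `Cc1ccc2[nH]c(=O)c(CN(Cc3ccc(OC(F)(F)F)cc3)Cc3ccc(C(C)(C)C)cc3)cc2c1` and compound 2 `CSc1ccc(CN(Cc2ccc(C(C)(C)C)cc2)Cc2cc3cc(C)ccc3[nH]c2=O)cc1` share the same core and differ in only one group. In a toxicity assay on MDCK cells (Canis lupus familiaris) for cytotoxicity, read by crystal violet staining, with a stated time of 48 h (on this read-out lower numbers stand for higher toxicity in this test and higher numbers for lower toxicity in this test), compound 1 gives > 5000 nM, which is a limit of the measurement rather than a number. In this assay compound 2 likewise gives > 5000 nM, again a limit. Among the compounds with values here, the single measured step, a step that the two limits leave unreadable from compound 1 to compound 2, therefore cannot be sized, because both of its values sit at the boundary that the limit of > 5000 nM in this assay, at which 2 of the 2 values shown sit, records. Compound 2 thus stands exactly where every value shown stands: at that limit.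

Compound 3 `Cc1ccc2[nH]c(=O)c(CN(Cc3ccc(C(C)(C)C)cc3)Cc3ccc(N(C)C)c(Cl)c3)cc2c1` has not yet been measured. It differs from compound 2 by 3-chloro-4-(dimethylamino)phenyl in place of 4-(methylsulfanyl)phenyl on a saturated chain carbon bound to an amine nitrogen. Within the data shown here, the only step that bears on this change is a step that the two limits leave unreadable from compound 1 to compound 2, which is unreadable, so there is no measured evidence for a shift in either direction beyond the scatter. Compound 3 is therefore expected to remain at or past the same boundary, an estimated step that the limit leaves unreadable from compound 2 to compound 3. The estimate for compound 3 in this assay is 8000 nM, within a range from 3000 nM to 30000 nM.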

Compound 3, half-maximal cytotoxic concentration: > 10000 nM
Compound 3 ended at the assay's limit; the forecaster's own chance of this, stated with the estimate: 80%; middle value at least 1.2-fold (0.09 log units) from the limit.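

Compound 3, like compound 1 and compound 2, gives a limit rather than a number in this assay, and none of the steps among the three can be read. The compounds shown leave open whether swapping these benzyl arms changes the concentration that harms the cells at all, and by how much.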